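The source may report more compounds than this note shows. Statements on the series, on what has been measured and on what is new or still open speak of the compounds shown alone.

Measured so far:
Compound 1, `Cc1c(F)c(N)c2c(=O)cc(-c3ccc(N)c(F)c3)oc2c1F`, in a functional assay on HeLa cells (Homo sapiens) for cytotoxicity, read by neutral red uptake, with a stated time of 3 days (on this read-out lower numbers stand for stronger inhibition and higher numbers for weaker inhibition), gives > 100000 nM, which is a limit of the assay and not a number.
Compound 2, `Nc1ccc(-c2cc(=O)c3c(N)c(F)c(Cl)c(F)c3o2)cc1F`, in this assay gives > 100000 nM, again a limit.
Compound 3, `CCOC(=O)c1c(F)c(N)c2c(=O)cc(-c3ccc(N)c(F)c3)oc2c1F`, in this assay gives > 100000 nM, also a limit.

All three compounds share one core and differ only in a single group on an aromatic carbon of that core. Because every value stops at the same limit, (the limit of > 100000 nM in this assay, at which 3 of the 3 values shown sit), none of the steps between them can be read: a step that the two limits leave unreadable from compound 1 to compound 2, a step that the two limits leave unreadable from compound 1 to compound 3 and a step that the two limits leave unreadable from compound 2 to compound 3. Compound 1 therefore stands at that limit, with nothing to set it apart from its two neighbours.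

The unmeasured compound 4, `CCCOCc1c(F)c(N)c2c(=O)cc(-c3ccc(N)c(F)c3)oc2c1F`, is reached from compound 1 by a change further out than those seen so far: propoxy in place of hydrogen on a saturated chain carbon bound to an aromatic carbon. Going by the values given here, no measured step addresses a change of this kind, and the three that exist are unreadable, so they give no direction. With all measured values at the limit, compound 4 is expected to stay there as well, the step from compound 1 being a step that the limit leaves unreadable from compound 1 to compound 4. The estimate for compound 4 in this assay is 150000 nM, within 50000 nM to 500000 nM.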

Compound 4, half-maximal inhibitory concentration: 78000 nM
Beside the measured number, compound 4's estimate is 1.9-fold (0.28 log units) above it; the range from low to high includes it.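

In this assay compound 4 is the only compound shown that gives a number rather than a limit, so the first reading in this series comes from a change on a saturated chain carbon bound to an aromatic carbon: propoxy in place of hydrogen there yields an at least 1.2-fold lower number from compound 1 to compound 4 (0.10 log units; that floor lies within the scatter). The comparisons with the other two neighbours read the same way, with propoxymethyl in place of ethoxycarbonyl yielding an at least 1.2-fold lower number from compound 3 to compound 4 (0.10 log units; that floor lies within the scatter) and propoxymethyl in place of chloro yielding an at least 1.2-fold lower number from compound 2 to compound 4 (0.10 log units; that floor lies within the scatter). All three steps are only floors, so they show that a number can be reached with this group but not how large the true change is, because the partner compounds stop at a limit: the limit of > 100000 nM in this assay, at which 3 of the 4 values shown sit.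

The compounds shown leave open whether the number goes with the ether oxygen or with the length of the chain, and a methoxymethyl group or a plain butyl chain on that carbon would help separate the two. They also leave open whether a longer ether chain, or an amine at the end of the chain, would give a step that clearly exceeds the scatter.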